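A few compounds are considered here, and "the series" means these few. Any claim that something is new, unique, unknown or untested is made for them only; others in the source may bear on it.

Working notes on the series, followed in an ADME assay on cells (Hepatocyte, Homo sapiens) for pharmacokinetics, read by LC-MS, with a stated time of 90 min, tested at 1 uM; a higher number here means faster removal of the compound, a lower number slower removal.

Compound 1, `C[C@H](Nc1c(NCCCCCC(=O)NO)c(=O)c1=O)c1ccccc1`, is the starting point. In this assay compound 1 gives < 5 uL/min, which is a limit of the assay and not a number. Compound 2, `Cc1ccccc1[C@H](C)Nc1c(NCCCCCC(=O)NO)c(=O)c1=O`, carries a methyl in place of hydrogen on an aromatic carbon. In this assay compound 2 gives < 5 uL/min, again a limit rather than a number. The step that the two limits leave unreadable from compound 1 to compound 2 is therefore not readable in size, since both of its ends sit at the limit of < 5 uL/min in this assay, at which 2 of the 2 values shown sit. Compound 2 thus stands at the limit of this assay, with no number of its own and no readable step to any measured neighbour.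

Compound 3, `Cc1ccc([C@H](C)Nc2c(NCCCCCC(=O)NO)c(=O)c2=O)cc1`, is the next to be measured. It differs from compound 2 as follows: 4-methylphenyl in place of 2-methylphenyl on a saturated chain carbon bound to a nitrogen on an aromatic ring and a saturated chain carbon. Among the compounds with values here, the only measured step that bears on this change is a step that the two limits leave unreadable from compound 1 to compound 2, and its size cannot be read from the two limits. With both measured compounds resting at the limit of < 5 uL/min in this assay, at which 2 of the 2 values shown sit, the expected step that the limit leaves unreadable from compound 2 to compound 3 is none beyond the scatter. Compound 3 is accordingly estimated at 4 uL/min, with a range from 1 uL/min to 12 uL/min, and is expected to be reported most likely as a limit once more.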

Compound 3, intrinsic clearance in a liver preparation (reported as CLH), per the amount of preparation that the assay uses in the Hepatocyte assay: < 5 uL/min
Compound 3 gave a limit, no number; the forecaster's own chance of this, stated with the estimate: 70%; the middle value lies beyond the limit too.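

Compound 3, like compounds 1 and 2, rests at a limit and not a number, so no new step among the three can be read from the results in the Hepatocyte assay here: the limit of < 5 uL/min in the Hepatocyte assay, at which 3 of the 3 values shown sit.

In a physicochemical assay for solubility, with a stated time of 24 h, tested at 30 mg/mL (on this read-out lower numbers stand for lower solubility and higher numbers for higher solubility), compound 2 gives 47000000 nM and compound 3 gives 5600000 nM with an 8.4-fold lower number from compound 2 to compound 3 (0.92 log units; beyond the scatter) on this read-out.

The compounds shown leave open how fast any of the three is actually removed in the Hepatocyte assay and whether any change to the shared core would lift a value off the limit.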